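The source may report more compounds than this note shows. Statements on the series, on what has been measured and on what is new or still open speak of the compounds shown alone.

Of the compounds shown here, three sharing one core have been measured in a physicochemical assay for solubility, read by HPLC, using the shake flask method, in phosphate buffer, with a stated time of 2 h, at pH 6.5; a higher number here means a more soluble compound, a lower number a less soluble compound. Compound 1 `CS(=O)(=O)c1ccc(-c2cnc(N)c(-c3ccc(N)nc3)n2)cc1` gives 149000 nM. Compound 2 `Nc1ncc(-c2ccc(C(=O)O)cc2)nc1-c1ccc(C(F)(F)F)cc1` gives 95000 nM, the second highest of the three numbers, though its gaps to both neighbours lie within the usual scatter. Compound 3 `Nc1ncc(-c2ccc(C(=O)N3CC[C@H](O)C3)cc2)nc1-c1ccc(C(F)(F)F)cc1` gives 68000 nM. Among the measured compounds shown here, the one single-point step among the measured compounds is a 1.4-fold lower number from compound 2 to compound 3 (0.15 log units; within the scatter), in which 3-hydroxypyrrolidin-1-yl replaces hydroxy on a carbonyl carbon.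

Compound 4 `COC(=O)c1ccc(-c2cnc(N)c(-c3ccc(C(F)(F)F)cc3)n2)cc1` differs from compound 2 in one place: methyl in place of hydrogen on an oxygen next to a carbonyl group. For the measured compounds named here, no measured pair shows this particular change, so the step from compound 2 to compound 3 is the nearest comparison, and it alters the same carbonyl group in a different way and stays within the scatter. The expectation for compound 4 therefore rests on thin ground, and the step is estimated as a 7.9-fold lower number from compound 2 to compound 4 (0.90 log units; beyond the scatter). Compound 4 is expected to give about 12000 nM, within a range from 2500 nM to 60000 nM.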

Compound 4, solubility: < 5000 nM
Compound 4 ended at the assay's limit (the forecaster's own chance of this, stated with the estimate: 5%); middle value at least 2.4-fold (0.38 log units) from the limit.
By their numbers in this assay, from the lowest: compounds 3, 2 and 1 (each within the scatter of the next, the first and the last beyond it). At a limit, below all of these: compound 4.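

Methyl in place of hydrogen on the oxygen next to the carbonyl group gives an at least 19-fold lower number from compound 2 to compound 4 (1.27 log units; beyond the scatter) in this assay, whereas the earlier change at this carbonyl carbon, from hydroxy to 3-hydroxypyrrolidin-1-yl, gave only a 1.4-fold lower number from compound 2 to compound 3 (0.15 log units; within the scatter). Methoxy in place of 3-hydroxypyrrolidin-1-yl on the same carbon gives an at least 13-fold lower number from compound 3 to compound 4 (1.13 log units; beyond the scatter), so at this position, methoxy stands well apart from both other groups, and a change of one methyl can outweigh the swap to a whole ring. The number for compound 4 is a limit, so both steps give only a minimum size: the limit of < 5000 nM in this assay, at which 1 of the 4 values shown sits.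

From the compounds shown here alone, how far the true value of compound 4 lies past that limit remains open. Going by these compounds, it also remains open whether ethoxy, a longer chain on this oxygen, or a plain amino group on the carbonyl carbon would behave like methoxy or like hydroxy.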